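From a Methoxyamide to a Hydroxypyrrolidine Amide

The source may hold more compounds than are shown below. What is called first, only, known or untested is meant among the compounds shown, and "the series" means these compounds.

Within the data shown here, compound 2 `CONC(=O)c1cccc(Oc2cc(CN)cc(C(F)(F)F)n2)c1` is the only member of this small set with a number in an ADME assay on the whole organism (lung, Mus musculus) for pharmacokinetics, read by LC-MS, at a dose of 30 mg/kg by the oral route (a higher number here means more compound in the circulation at the dose given, a lower number less compound in the circulation), where compound 2 gives 8780 nM. Compound 1 `NCc1cc(Oc2cccc(Oc3ccccc3)c2)nc(C(F)(F)F)c1` was also run in this assay, where compound 1 is recorded as "not determined" (no result reported). Compound 3 `NCc1cc(Oc2cccc(C(=O)NCc3cc4ccccc4s3)c2)nc(C(F)(F)F)c1` was run there too, and compound 3 is recorded as "not determined" (no result reported), so compound 2 stands alone as the single point of reference. Compound 4 `NCc1cc(Oc2cccc(C(=O)N3CC[C@@H](O)C3)c2)nc(C(F)(F)F)c1` is the compound still to be measured. It differs from compound 2 in one place: 3-hydroxypyrrolidin-1-yl in place of methoxyamino on a carbonyl carbon. No step between two measured compounds exists to calibrate this change, so its effect in this assay cannot be read from any shown pair. The step is expected to be small, within or only slightly beyond the scatter, and if anything downward, as a 1.5-fold lower number from compound 2 to compound 4 (0.17 log units; within the scatter). Compound 4 is therefore estimated to give 6000 nM, with a plausible range from 2000 nM to 18000 nM.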

Compound 4, maximal plasma concentration: 9130 nM
For compound 4 the middle estimate is 1.5-fold (0.18 log units) below the measured one, within the range that was stated.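

In this assay, among these compounds, the first readable step at this position is a 1.0-fold higher number from compound 2 to compound 4 (0.02 log units; within the scatter), with 3-hydroxypyrrolidin-1-yl in place of methoxyamino on a carbonyl carbon. The position therefore accommodates a change from 3 heavy atoms and no ring to 6 heavy atoms and a five-membered non-aromatic ring, with a defined stereocentre, without the read-out leaving the scatter, while the counts of hydrogen-bond donors and acceptors stay the same. No supporting measurement bears on why the two compounds read alike.

Steps to compound 1 and compound 3 cannot be read. Still open, on these data alone, is whether the same holds on this carbonyl carbon for pyrrolidin-1-yl without the hydroxyl, for morpholin-4-yl or for a carboxylic acid, and for the opposite configuration at the stereocentre.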